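The source may report more compounds than this note shows. Statements on the series, on what has been measured and on what is new or still open speak of the compounds shown alone.

Compound 1 `CCCCCCCCCNC(=O)N(Cc1cc(OC)ccc1OC)n1cnnc1` gives a limit, > 50000 nM.
Compound 2 `Cc1ccsc1CN(C(=O)Nc1ccccc1)n1cnnc1` gives a limit, > 50000 nM.
Compound 3 `Cc1ccsc1CN(C(=O)Nc1cccc(Cl)c1)n1cnnc1` gives 40300 nM.

Within the data shown here, in a functional assay on MDA-MB-231 cells (Homo sapiens) for cytotoxicity, read by MTT assay, with a stated time of 48 h (a lower number here means a stronger inhibitor, a higher number a weaker inhibitor), compound 3 holds the only number among the three; the other two values are a limit. Among the measured compounds shown here, the single measured step, an at least 1.2-fold lower number from compound 2 to compound 3 (0.09 log units; that floor lies within the scatter), has its floor at the limit (the limit of > 50000 nM in this assay, at which 2 of the 3 values shown sit), so it says little about how much an aromatic substituent moves the number. Compound 4 `Cc1ccsc1CN(C(=O)Nc1cccc(C#N)c1)n1cnnc1` differs from compound 3 by cyano in place of chloro on an aromatic carbon. For the measured compounds named here, no measured step exchanges these two groups, and the one step that bears on substitution at this place, an at least 1.2-fold lower number from compound 2 to compound 3 (0.09 log units; that floor lies within the scatter), lies within the scatter. Near the number of compound 3, compound 4 is therefore expected at 45000 nM, a step of a 1.1-fold higher number from compound 3 to compound 4 (0.05 log units; within the scatter), with a range from 18000 nM to 100000 nM.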

Compound 4, half-maximal inhibitory concentration: > 50000 nM
Compound 4: only a limit was reported; the forecaster's own chance of this, stated with the estimate: 45%; middle value at least 1.1-fold (0.04 log units) from the limit.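

In this assay, cyano in place of chloro on this aromatic carbon gives an at least 1.2-fold higher number from compound 3 to compound 4 (0.09 log units; that floor lies within the scatter), so the cyano compound offers no second number to set beside that of compound 3. The step from compound 2 to compound 4 cannot be read, as both values are limits. The series at this place now rests mostly on one ceiling: the limit of > 50000 nM in this assay, at which 3 of the 4 values shown sit.

From the compounds shown here alone, how far compound 4 lies past its limit stays open. So does whether an amine or a carboxylic acid on this aromatic carbon would give a number clearly apart from that of compound 3.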